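Changing One Aromatic Group in a Level Series

The compounds below may be only part of what the source reports. "The series", "measured", "known", "first", "only" and "open" are said of these compounds alone.

- compound 1 `COc1ccccc1/C=C(\C(=O)c1ccc(Br)cc1)S(=O)(=O)c1ccc(C)cc1`: 1000 nM
- compound 2 `COc1ccccc1/C=C(\C(=O)c1ccc(Cl)cc1)S(=O)(=O)c1ccc(C)cc1`: 1000 nM
- compound 3 `Cc1ccc(S(=O)(=O)/C(=C/c2ccccc2OCc2ccccc2)C(=O)c2ccc(Br)cc2)cc1`: 1000 nM

In a functional assay on DU-145 cells (Homo sapiens) for inhibition, read by trypan blue exclusion, with a stated time of 96 h (a higher number here means a weaker inhibitor of growth, a lower number a stronger inhibitor of growth), compound 1 gives 1000 nM, level with the other two measured compounds. Compound 4 `Cc1ccc(S(=O)(=O)/C(=C/c2ccc(F)cc2F)C(=O)c2ccc(Br)cc2)cc1` keeps the rest of compound 1 and changes one group: 2,4-difluorophenyl in place of 2-methoxyphenyl on a double-bonded chain carbon bound to a double-bonded chain carbon. In words, 2,4-difluorophenyl stands in place of 2-methoxyphenyl on a double-bonded chain carbon bound to a double-bonded chain carbon.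

Two measured steps offer indirect guidance. The closer one alters the 2-methoxyphenyl group itself, with phenyl in place of hydrogen on a saturated chain carbon bound to an oxygen on an aromatic ring: no change at the digits printed from compound 1 to compound 3 (within the scatter). The other is a chloro in place of bromo on an aromatic carbon: no change at the digits printed from compound 1 to compound 2 (within the scatter). Neither step replaces the whole group or introduces fluorine, so the data do not test this change directly. Since neither step moved the value, no change beyond the scatter is expected, although with real uncertainty. The expected step is no change at the digits printed from compound 1 to compound 4 (within the scatter). The estimate for compound 4 is 1000 nM, with an expected range of 400 nM to 3000 nM.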

Compound 4, concentration for 50% growth inhibition: > 100000 nM
Compound 4 was reported as a limit; the forecaster's own chance of this, stated with the estimate: 10%; middle value at least 100-fold (2.00 log units) away from the limit.
By their numbers in this assay, from the lowest: compounds 1, 2 and 3 (each within the scatter of the next). At a limit, above all of these: compound 4.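

Going by these compounds alone, the group on this double-bonded chain carbon clearly matters: exchanging it whole gives an at least 100-fold higher number from compound 1 to compound 4 (2.00 log units; beyond the scatter), whereas the earlier steps left the number level. Compound 1 and compound 3 both keep an oxygen on this aromatic ring, while compound 4 has none, so the room for change seen from compound 1 to compound 3 did not extend to this exchange. The result for compound 4 in this assay is a limit, not a number: the limit of > 100000 nM in this assay, at which 1 of the 4 values shown sits.

The change removes the methoxy group and adds two fluorines at once, and the compounds shown cannot tell which of these matters, or whether both do. Nor do they show how an unsubstituted phenyl, a ring with a single fluorine or a ring bearing an amine would behave here.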